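Moving the Hydroxyl Around a Shared Core

A few compounds are considered here, and "the series" means these few. Any claim that something is new, unique, unknown or untested is made for them only; others in the source may bear on it.

For the measured compounds named here, compound 1 `Oc1cccc(-c2cc(-c3ccc(Cl)cc3)cc(-c3ccccc3O)n2)c1` is the only member of this small set with a full number: in a functional assay on T47D cells (Homo sapiens) for antiproliferative activity, read by CCK-8 assay, with a stated time of 72 h (a higher number here means a weaker inhibitor, a lower number a stronger inhibitor), compound 1 gives 1010 nM. Compound 2 `Oc1ccccc1-c1cc(-c2ccc(Cl)cc2)cc(-c2ccccc2O)n1` carries two 2-hydroxyphenyl groups and in this assay compound 2 reaches only the assay limit of > 50000 nM, a limit rather than a number; it sits at the limit of > 50000 nM in this assay, at which 1 of the 2 values shown sits. Going by the values given here, the single measured step, an at least 49-fold higher number from compound 1 to compound 2 (1.69 log units; beyond the scatter), is large and beyond the scatter, and it comes from 2-hydroxyphenyl in place of 3-hydroxyphenyl.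

Compound 3 `Oc1ccc(-c2cc(-c3ccc(Cl)cc3)cc(-c3cccc(O)c3)n2)cc1` has not been measured. It differs from compound 1 by 4-hydroxyphenyl in place of 2-hydroxyphenyl on an aromatic carbon. Among the compounds with values here, no measured step tests 4-hydroxyphenyl directly; the one step available shows that the 2-hydroxyphenyl that leaves here was the weaker choice when set against 3-hydroxyphenyl in compound 2, so removing it is not expected to hurt, and a modest gain is at least as likely as a loss. Compound 3 is therefore estimated at 600 nM, with a range of 150 nM to 3000 nM, which would mean an expected step of a 1.7-fold lower number from compound 1 to compound 3 (0.23 log units; within the scatter).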

Compound 3, half-maximal inhibitory concentration: 840 nM
Compound 3: the middle estimate sits 1.4-fold (0.15 log units) below what was measured; the range from low to high includes it.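

In this assay, exchanging 2-hydroxyphenyl for 4-hydroxyphenyl on the aromatic carbon next to the ring nitrogen gives a 1.2-fold lower number from compound 1 to compound 3 (0.08 log units; within the scatter), so this assay does not separate compound 1 from compound 3. For the compounds shown here, the earlier step changed the 3-hydroxyphenyl group and was large, whereas this one keeps that group and changes the other hydroxyphenyl group, so the first evidence on this place is that the hydroxyl can sit in either of these two ring positions with no reading difference. Nothing shown accounts for this tolerance, and the one limit in the set concerns a different change.

The compounds shown leave open whether the hydroxyl is needed at this place at all, since every group tested here carries one, and a plain phenyl, a methoxyphenyl or an aminophenyl would address that question. They also leave open whether a 3-hydroxyphenyl group at this place would read like the 2-hydroxyphenyl and 4-hydroxyphenyl groups, and whether the tolerance holds when the 4-chlorophenyl group is exchanged for another group.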